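Urea pair on a pyrazole core, tested for thermal stabilisation

A few compounds are considered here, and "the series" means these few. Any claim that something is new, unique, unknown or untested is made for them only; others in the source may bear on it.

Of the compounds shown here, two have been measured so far. Compound 1 `CC(C)(C)c1cc(NC(=O)Nc2cc(F)cc(F)c2)n(C(C)(C)C)n1` gives 0 degrees C in an assay on isolated protein for inhibition of Ephrin type-A receptor 2 (Homo sapiens), read by thermal shift assay, tested at 10 uM; a lower number here means that the compound stabilises the target less, a higher number that the compound stabilises the target more against heat. Compound 2 `CC(C)(C)c1cc(NC(=O)Nc2ccc(Cl)cc2)n(-c2ccc(C(F)(F)F)cc2)n1` gives 0.6 degrees C in this assay, the higher of the two numbers, though its gap to compound 1 lies within the scatter of this kind of measurement, so neither compound can be said to stabilise the target more than the other.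

Compound 3 `CC(C)C(=O)Nc1ccc(-n2nc(C(C)(C)C)cc2NC(=O)Nc2ccc(Cl)cc2)cc1` has not yet been measured. It differs from compound 2 in one place: (isopropylcarbonyl)amino in place of trifluoromethyl on an aromatic carbon. For the measured compounds named here, no measured pair shows what such a swap does, so the size of the step is unknown. Both measured values sit close to zero, and no change beyond the scatter is expected from compound 2 to compound 3, in either direction. The expected step is a number 0.10 degrees C lower from compound 2 to compound 3 (within the scatter). Compound 3 is estimated at 0.5 degrees C, within a range from -0.5 degrees C to 2 degrees C.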

Compound 3, shift of the target's melting temperature: 2.8 degrees C
The estimate for compound 3 lay 2.3 degrees C below the measured number, outside the stated range (above it).
By their numbers in this assay, from the lowest: compounds 1 and 2 (each within the scatter of the next); then compound 3.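

In this assay, putting (isopropylcarbonyl)amino in place of trifluoromethyl on this aromatic carbon, para to a large group, gives a reading a number 2.2 degrees C higher from compound 2 to compound 3 (beyond the scatter) and is the only step shown between compounds that differ in one place. It shows that a change at this position alone can move the reading by more than the usual scatter, with the entering group bringing one hydrogen-bond donor and one hydrogen-bond acceptor where the leaving group has neither. No measurement at hand explains the step.

On these data alone, it remains open which part of the (isopropylcarbonyl)amino group goes with the higher reading: the amide hydrogen, the carbonyl or the isopropyl end. A plain amine, or an amide with a longer chain, at this position would help to separate these parts.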